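Styryl sulfone series: adding cyano to compound 1

The source may report more compounds than this note shows. Statements on the series, on what has been measured and on what is new or still open speak of the compounds shown alone.

Measured so far in a functional assay on DU-145 cells (Homo sapiens) for inhibition; a higher number here means a weaker inhibitor of growth, a lower number a stronger inhibitor of growth:
- compound 1 `O=S(=O)(/C=C/c1ccccc1)Cc1ccc(Nc2ncnc3ccccc23)cc1` gives 2000 nM
- compound 2 `O=S(=O)(/C=C/c1ccc(F)cc1)Cc1ccc(Nc2ncnc3ccccc23)cc1` gives 300 nM

Compound 1 holds the higher of the two numbers, so it is the weaker growth inhibitor of the pair. Compound 3 `N#Cc1ccc(/C=C/S(=O)(=O)Cc2ccc(Nc3ncnc4ccccc34)cc2)cc1` has not yet been measured. It differs from compound 1 in one place: cyano in place of hydrogen on an aromatic carbon. This is cyano in place of hydrogen on an aromatic carbon, para to a large group, which turns phenyl to 4-cyanophenyl.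

Among the measured compounds shown here, one measured step bears on this change, also a replacement of hydrogen on an aromatic carbon. With fluoro entering, the step is a 6.7-fold lower number from compound 1 to compound 2 (0.82 log units; beyond the scatter), modest in size but clear of the scatter. For the measured compounds named here, no measured compound carries cyano, so this single step is only a loose guide. A lower number is expected, in the same direction as that step and perhaps somewhat smaller. The expected step is a 3.3-fold lower number from compound 1 to compound 3 (0.52 log units; beyond the scatter) in this assay. For compound 3 the estimated value is 600 nM, with an expected range from 150 nM to 2500 nM.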

Compound 3, concentration for 50% growth inhibition: > 100000 nM
Compound 3 gave a limit, no number (the forecaster's own chance of this, stated with the estimate: 3%); middle value at least 160-fold (2.22 log units) away from the limit.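

In this assay compound 3 gives > 100000 nM, a limit of the assay and not a number. Replacing hydrogen at this aromatic carbon, para to a large group, is therefore not a one-way change: against a 6.7-fold lower number from compound 1 to compound 2 (0.82 log units; beyond the scatter), cyano gives an at least 50-fold higher number from compound 1 to compound 3 (1.69 log units; beyond the scatter), and exchanging fluoro for cyano gives an at least 330-fold higher number from compound 2 to compound 3 (2.52 log units; beyond the scatter). So the identity of the group entering this position decides the direction of the step, and the single fluoro step gave no sign of this; the full size of both new steps remains unknown because the value for compound 3 is a limit: the limit of > 100000 nM in this assay, at which 1 of the 3 values shown sits.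

With only hydrogen, fluoro and cyano at this position, the compounds shown do not tell whether the sharp rise in the number belongs to cyano alone or extends to other groups. Chloro, methoxy, an amine or a carboxylic acid on the same aromatic carbon would show how far the fluoro result or the cyano result carries across the series.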